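The compounds below may be only part of what the source reports. "The series", "measured", "known", "first", "only" and "open" are said of these compounds alone.

Measured compounds in an ADME assay on HEK293 cells (Homo sapiens) for antiproliferative activity, read by MTT assay, with a stated time of 24 h; on this read-out lower numbers stand for stronger inhibition and higher numbers for weaker inhibition:

compound 1 `COc1ccc(-c2cc(/C=C/C(=O)c3cc(OC)c(OC)c(OC)c3)nc3cc(-c4ccccc4)nn23)cc1OC` — compound 1 gives 35000 nM
compound 2 `COc1ccc(-c2cc(/C=C/C(=O)c3ccccc3)nc3cc(-c4ccccc4)nn23)cc1OC` — compound 2 gives 51200 nM
compound 3 `COc1ccc(-c2cc(C(=O)/C=C/c3ccc(Cl)cc3)nc3cc(-c4ccccc4)nn23)cc1OC` — compound 3 gives 39100 nM

Compound 2 carries the highest of the three numbers in this assay, but both of its steps to the others are within the scatter: a 1.5-fold higher number from compound 1 to compound 2 (0.17 log units; within the scatter) and a 1.3-fold lower number from compound 2 to compound 3 (0.12 log units; within the scatter). On these numbers the three compounds cannot be separated.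

Compound 4 `COc1cc(-c2cc(/C=C/C(=O)c3ccccc3)nc3cc(-c4ccccc4)nn23)cc(OC)c1OC` is not yet measured. It differs from compound 2 in one place: methoxy in place of hydrogen on an aromatic carbon

Among the measured compounds shown here, no measured step alters this ring. The nearest comparison is a 1.5-fold higher number from compound 1 to compound 2 (0.17 log units; within the scatter), where the number of methoxy groups changes on the group on a carbonyl carbon, and that step stays within the scatter; a 1.3-fold lower number from compound 2 to compound 3 (0.12 log units; within the scatter) concerns a different part of the molecule and also stays within the scatter. For the measured compounds named here, with no step leaving the scatter, no shift beyond the scatter is expected for compound 4 in this assay, in either direction.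

Compound 4 is therefore estimated at 45000 nM in this assay, with a range of 20000 nM to 100000 nM, the expected step being a 1.1-fold lower number from compound 2 to compound 4 (0.06 log units; within the scatter).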

Compound 4, half-maximal inhibitory concentration: >= 100000 nM
Compound 4: no number, only a limit; the forecaster's own chance of this, stated with the estimate: 15%; middle value at least 2.2-fold (0.34 log units) away from the limit.
By their numbers in this assay, from the lowest: compounds 1, 3 and 2 (each within the scatter of the next). At a limit, above all of these: compound 4.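

In this assay compound 4 gives a limit of the assay, not a number: the limit of >= 100000 nM in this assay, at which 1 of the 4 values shown sits.

Among the compounds shown here, this is the first reading for a change on the 3,4-dimethoxyphenyl ring, where 3,4,5-trimethoxyphenyl replaces it, and it reads as an at least 1.9-fold higher number from compound 2 to compound 4 (0.29 log units; that floor lies within the scatter). On these data alone, the floor of that step does not separate compound 4 from compound 2, so its true size is unknown, but the added methoxy gives no sign of a lower number at this position, and the earlier methoxy step concerned only the group on a carbonyl carbon.

As far as these compounds go, whether the true value of compound 4 lies beyond the scatter from compound 2 stays open, as does whether the same change would read alike with the 3,4,5-trimethoxyphenyl group of compound 1 on the carbonyl carbon. Also open, from the compounds shown here alone, is what a hydroxy group, an ethoxy group or an amine would give at this place.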